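Compound 3 to compound 4: methoxy swapped for methyl

The compounds below may be only part of what the source reports. "The series", "measured", "known", "first", "only" and "open" are said of these compounds alone.

Going by the values given here, compound 3 (`COc1ccc(N2C(=O)COc3ccc(-c4cccc(NS(=O)(=O)c5ccc(F)cc5)c4)cc32)cc1`) gives 28300 nM in a functional assay on HCT-116 cells (Homo sapiens) for antiproliferative activity, read by MTT assay, with a stated time of 72 h (on this read-out lower numbers stand for stronger inhibition and higher numbers for weaker inhibition), the only real number so far. Compound 1 (`O=C1COc2ccc(-c3cccc(NS(=O)(=O)c4ccc(F)cc4)c3)cc2N1`) reads > 40000 nM, which is a limit of the assay. Compound 2 (`O=C1COc2ccc(-c3cccc(NS(=O)(=O)c4ccc(F)cc4)c3)cc2N1c1ccccc1`) reads > 40000 nM, also a limit.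

Compound 4 (`Cc1ccc(N2C(=O)COc3ccc(-c4cccc(NS(=O)(=O)c5ccc(F)cc5)c4)cc32)cc1`) has methyl in place of methoxy on an aromatic carbon, para to a large group: methyl in place of methoxy on an aromatic carbon.

Among the compounds with values here, three measured steps bear on this change. Adding phenyl gives a step that the two limits leave unreadable from compound 1 to compound 2. Adding 4-methoxyphenyl gives an at least 1.4-fold lower number from compound 1 to compound 3 (0.15 log units; that floor lies within the scatter). The closest guide is methoxy in place of hydrogen, an at least 1.4-fold lower number from compound 2 to compound 3 (0.15 log units; that floor lies within the scatter). None of these shows an effect beyond the scatter, so no step beyond the scatter is expected in this assay, and no direction can be assigned. Compound 4 could well end at the limit of > 40000 nM in this assay, at which 2 of the 3 values shown sit.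

The expected change is small, a 1.1-fold higher number from compound 3 to compound 4 (0.03 log units; within the scatter). For compound 4 the estimated value is 30000 nM, with an expected range of 14000 nM to 60000 nM.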

Compound 4, half-maximal inhibitory concentration: 35600 nM
Compound 4: the middle estimate sits 1.2-fold (0.07 log units) below what was measured; measured number inside the range.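

In this assay the exchange of 4-methoxyphenyl for 4-methylphenyl can now be read between two real numbers, and it gives a 1.3-fold higher number from compound 3 to compound 4 (0.10 log units; within the scatter). Set against the compounds without this substituent, methyl gives an at least 1.1-fold lower number from compound 2 to compound 4 (0.05 log units; that floor lies within the scatter), and the whole 4-methylphenyl group gives an at least 1.1-fold lower number from compound 1 to compound 4 (0.05 log units; that floor lies within the scatter), so neither shows a step beyond the scatter. Methoxy and methyl at this position therefore cannot be told apart on this read-out, and the steps from compound 1 and compound 2 remain floors only: the limit of > 40000 nM in this assay, at which 2 of the 4 values shown sit.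

As far as these compounds go, whether a dimethylamino group, a carboxylic acid or a longer alkyl chain at this position would move the number beyond the scatter stays open. Also open, from the compounds shown here alone, is how far compound 1 and compound 2 really lie from compound 3 and compound 4.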